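Removing a chloro group: what compound 4 may tolerate

This account rests on a few compounds, and the source may have more. Where it says the series, first, only, none or still open, it means among the compounds named here.

Three measured compounds share one tolerated level:
Compound 1, `CN1CCN(Cc2c([O-])on[n+]2-c2ccc(Cc3ccc(-[n+]4noc([O-])c4CN4CCN(C)C(c5ccccc5)C4)cc3)cc2)CC1c1ccccc1`: 100 ug/mL
Compound 2, `Cc1ccc(-[n+]2noc([O-])c2CN2CCN(c3cccc(Cl)c3)CC2)cc1`: 100 ug/mL
Compound 3, `[O-]c1on[n+](-c2ccc(Cc3ccc(-[n+]4noc([O-])c4CN4CCNCC4)cc3)cc2)c1CN1CCNCC1`: 100 ug/mL

All three were tested in an ADME assay on HEL cells (Homo sapiens) for cytotoxicity; a higher number here means that more compound is tolerated, a lower number that less compound is tolerated. Compound 2 stands level with compounds 1 and 3 at the digits shown; its nearest by value is compound 1 and its furthest is compound 3, yet both gaps fall within the scatter, so no order can be read among them. Compound 4, `Cc1ccc(-[n+]2noc([O-])c2CN2CCN(c3ccccc3)CC2)cc1`, is still to be measured. It differs from compound 2 in one place: hydrogen in place of chloro on an aromatic carbon. Within the data shown here, no step between measured compounds differing in a single place has been recorded, so the size of this change can only be expected. The step of no change at the digits printed from compound 2 to compound 4 (within the scatter) is expected to be none beyond the scatter. Compound 4 is therefore estimated at 100 ug/mL, within a range from 50 ug/mL to 200 ug/mL.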

Compound 4, minimum cytotoxic concentration: 100 ug/mL
Estimate against measurement, compound 4: no gap at the digits printed, and the stated range covers the measured number.
By their numbers in this assay, from the lowest: compounds 1, 2, 3 and 4 (each within the scatter of the next).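

In this assay, among these compounds, the first step between compounds differing in one place reads no change at the digits printed from compound 2 to compound 4 (within the scatter) and so gives a direct comparison at this position. Here, 3-chlorophenyl and phenyl cannot be told apart, so this aromatic carbon carries either chloro or hydrogen with no readable shift in tolerated concentration. No measured evidence bears on why this is so. From the compounds shown here alone, whether an amine, a carboxylic acid or a methoxy group on the same carbon would also leave the value in place remains open, as does whether this change would read the same on another core.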